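From one ring to two: estimating compound 4

The source may hold more compounds than are shown below. What is called first, only, known or untested is meant among the compounds shown, and "the series" means these compounds.

In a physicochemical assay for solubility, in phosphate buffer, at pH 7.4 (a lower number here means a less soluble compound, a higher number a more soluble compound), compound 2 `CC(=O)N[C@@H]1CCC[C@H](C(=O)Nc2cc(-c3cnc(C)n3C)c(Cl)cn2)C1` gives > 1000000 nM. That reading is a limit of the assay, not a number. Two relatives differ from it only in the group on the aromatic carbon opposite the ring nitrogen. Compound 1 `CC(=O)N[C@@H]1CCC[C@H](C(=O)Nc2cc(-c3cnn4ccccc34)c(Cl)cn2)C1` gives 45000 nM, and compound 3 `CC(=O)N[C@@H]1CCC[C@H](C(=O)Nc2cc(-c3cnc4n3CCC4)c(Cl)cn2)C1` gives 490000 nM.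

Compound 4 `CC(=O)N[C@@H]1CCC[C@H](C(=O)Nc2cc(-c3cnn4c3NCCC4)c(Cl)cn2)C1` has not yet been measured. In it, the 1,2-dimethyl-1H-imidazol-5-yl group of compound 2 gives way to a group with one five-membered aromatic ring and one six-membered non-aromatic ring: a group of 9 heavy atoms (6 carbon, 3 nitrogen; one five-membered aromatic ring with 2 hetero atoms, one six-membered non-aromatic ring with 2 hetero atoms) in place of a group of 7 heavy atoms (5 carbon, 2 nitrogen; one five-membered aromatic ring with 2 hetero atoms), on an aromatic carbon.

For the measured compounds named here, three measured steps bear on this change. Two are large and beyond the scatter: an at least 22-fold higher number from compound 1 to compound 2 (1.34 log units; beyond the scatter) and an 11-fold higher number from compound 1 to compound 3 (1.04 log units; beyond the scatter). The third is an at least 2.0-fold lower number from compound 2 to compound 3 (0.30 log units; that floor lies within the scatter), and its floor lies within the scatter. Compound 3, at 490000 nM, is the closest guide, as its group also joins a five-membered aromatic ring to a non-aromatic ring. A lower number than for compound 2 is therefore expected, though probably not as low as for compound 1. The estimated step is an at least 4.0-fold lower number from compound 2 to compound 4 (0.60 log units; beyond the scatter). For compound 4, the expected value is 250000 nM, with an estimated range from 70000 nM to 800000 nM.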

Compound 4, solubility: 860000 nM
Estimate against measurement, compound 4: 3.4-fold (0.54 log units) below; measured number outside the range, above it.
By their numbers in this assay, from the lowest: compound 1; then compounds 3 and 4 (each within the scatter of the next). At a limit, above all of these: compound 2.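

In this assay, compounds 3 and 4 lie within the scatter of each other: a 1.8-fold higher number from compound 3 to compound 4 (0.24 log units; within the scatter). The earlier compounds shown here showed a five-membered aromatic ring joined to a five-membered non-aromatic ring at this position, opposite the ring nitrogen, and the new result shows that a six-membered non-aromatic ring with 2 hetero atoms keeps the number in the same region. The comparison with the two aromatic rings of compound 1 adds a second point: a 19-fold higher number from compound 1 to compound 4 (1.28 log units; beyond the scatter), and since the groups in that step have the same number of heavy atoms, group size alone does not set the number here.

The step from compound 2 gives only a floor: an at least 1.1-fold lower number from compound 2 to compound 4 (0.06 log units; that floor lies within the scatter). Its size cannot be read, because compound 2 stands at a limit of the assay and not at a number: the limit of > 1000000 nM in this assay, at which 1 of the 4 values shown sits. The compounds shown also leave open how much the hydrogen on the non-aromatic ring nitrogen of the new group counts, which a methyl group in its place, or an open dimethylamino chain in place of that ring, could begin to show.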